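Adding a methyl next to the amide in a fast-clearing series

A few compounds are considered here, and "the series" means these few. Any claim that something is new, unique, unknown or untested is made for them only; others in the source may bear on it.

Of the compounds shown here, two have been tested in an ADME assay for pharmacokinetics; a higher number here means that the compound lasts longer, a lower number that the compound disappears faster. Compound 1, with the structure `COc1ccc(NC(=O)C(C)Nc2c([N+](=O)[O-])cc(C(=O)NCC(O)CO)cc2[N+](=O)[O-])cc1`, gives a result of < 0.0167 h in this assay, which is a limit of the assay and not a number. Compound 2, with the structure `COc1ccc(NC(=O)C(C)Nc2c([N+](=O)[O-])cc(C(=O)NCCO)cc2[N+](=O)[O-])cc1`, also gives a result of < 0.0167 h in this assay, again a limit rather than a number. The step from compound 1 to compound 2, which replaces a hydroxymethyl by hydrogen, is therefore a step that the two limits leave unreadable from compound 1 to compound 2. Compound 2 stands at the limit of < 0.0167 h in this assay, at which 2 of the 2 values shown sit, so both measured values sit at the same limit and no ordering can be read between them.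

Compound 3, with the structure `COc1ccc(NC(=O)C(C)(C)Nc2c([N+](=O)[O-])cc(C(=O)NCCO)cc2[N+](=O)[O-])cc1`, is the next compound. Compared with compound 2 the change is methyl in place of hydrogen on a saturated chain carbon bound to a carbonyl carbon, a nitrogen on an aromatic ring and a saturated chain carbon. Going by the values given here, no measured step covers this change, and the only measured step is unreadable, so there is nothing to point the expectation up or down. Compound 3 is therefore expected to stay where compound 2 stands, with an estimated step that the limit leaves unreadable from compound 2 to compound 3 in this assay. The estimated value for compound 3 is 0.012 h, within a range from 0.004 h to 0.05 h, most likely reported again as a limit.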

Compound 3, half-life: < 0.0167 h
Compound 3: a limit, no number; the forecaster's own chance of this, stated with the estimate: 80%; the middle value lies beyond the limit too.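

In this assay compound 3 gives < 0.0167 h, which is a limit of the assay and not a number, so the step from compound 2 to compound 3, methyl in place of hydrogen, cannot be read. The compounds shown leave open how long each one actually lasts, and whether this methyl changes that at all.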